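A few compounds are considered here, and "the series" means these few. Any claim that something is new, unique, unknown or untested is made for them only; others in the source may bear on it.

Of the compounds shown here, three of one shared core have been measured so far, and a fourth awaits its number. Compound 1 `Cc1ccccc1-n1nc(C)c2c1NC(=O)[C@H](C)S[C@@H]2c1ccc(-c2ccoc2)cc1` carries a furan-3-yl group on one of its aromatic rings. In an assay on isolated protein for agonist activity at Bile acid receptor (Homo sapiens), read by AlphaScreen, with a stated time of 30 min (a lower number here means that less compound is needed, a higher number that more compound is needed for the effect), compound 1 gives 3500 nM. Compound 2 `COc1ccc(C2SC(C)C(=O)Nc3c2c(C)nn3-c2ccccc2C)c(OC)c1`, which carries two methoxy groups on that ring instead, gives 10500 nM in this assay. Compound 3 `CCCc1ccccc1-n1nc(C)c2c1NC(=O)[C@H](C)S[C@@H]2c1ccc(Oc2ccccc2)cc1`, with a phenoxy group in the same region and a propyl chain elsewhere, gives 1100 nM. Among these three numbers compound 1 holds the second highest: compound 2 sits at a higher number, and compound 3 at a lower one, and both of those gaps lie beyond the usual scatter of this assay.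

Compound 4 `COc1ccccc1-c1ccc([C@H]2S[C@@H](C)C(=O)Nc3c2c(C)nn3-c2ccccc2C)cc1` has not yet been measured. It differs from compound 1 in one place: 2-methoxyphenyl in place of furan-3-yl on an aromatic carbon. For the measured compounds named here, no pair of measured compounds shows exactly this exchange, so its effect can only be guessed from the surrounding numbers. A somewhat larger aromatic group in this region is seen together with a lower number in compound 3, while compound 2 shows that more oxygen-bearing substitution there does not guarantee one. The step of a 1.8-fold lower number from compound 1 to compound 4 (0.24 log units; within the scatter) is therefore expected to be modest, toward a lower number, and possibly within the scatter. For compound 4 the estimated value in this assay is 2000 nM, with a likely range from 700 nM to 6000 nM.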

Compound 4, half-maximal effective concentration: 1100 nM
Estimate against measurement, compound 4: 1.8-fold (0.26 log units) above, within the range that was stated.
By their numbers in this assay, from the lowest: compounds 3 and 4 (each within the scatter of the next); then compound 1; then compound 2.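

In this assay, for the compounds shown here, replacing furan-3-yl with 2-methoxyphenyl gives a 3.2-fold lower number from compound 1 to compound 4 (0.50 log units; beyond the scatter) and is the only step here in which just one place changes, so this difference can be tied to that exchange alone. It shows that this position, on an aromatic carbon para to a large group, accepts a six-membered aromatic ring of carbon only with 8 heavy atoms in place of a five-membered aromatic ring with 5 heavy atoms, and that the number falls although the count of 1 hydrogen-bond acceptor and 0 donors stays the same. No measurement available here accounts for this step.

On these data alone, what stays open is whether the lower number goes with the six-membered ring itself or with its methoxy group, and a plain phenyl group at this position would separate the two. Also open, as far as these compounds go, is how a methoxy group elsewhere on that ring, or an amine or a carboxylic acid on the same aromatic carbon, would read in this assay.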